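The source may hold more compounds than are shown below. What is called first, only, known or untested is meant among the compounds shown, and "the series" means these compounds.

Working notes on the series, read in a functional assay on A549 cells (Homo sapiens) for antiproliferative activity, read by MTT assay, with a stated time of 72 h; on this read-out lower numbers stand for stronger inhibition and higher numbers for weaker inhibition. Of the compounds shown here, three have values so far, differing on an amine nitrogen in a ring: compound 1 `CN1CCN(C(=S)SCc2ccc3nc(N)nc(N)c3c2)CC1` gives 9200 nM, compound 2 `COc1ccc(N2CCN(C(=S)SCc3ccc4nc(N)nc(N)c4c3)CC2)cc1` gives 1590 nM, and compound 3 `Nc1nc(N)c2cc(CSC(=S)N3CCN(c4ccc(Cl)c(Cl)c4)CC3)ccc2n1` gives 2940 nM. Compound 2 sits within the scatter of compound 3 and beyond the scatter from compound 1, with a 5.8-fold lower number from compound 1 to compound 2 (0.76 log units; beyond the scatter).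

Compound 4 `Nc1nc(N)c2cc(CSC(=S)N3CCN(c4ccccc4F)CC3)ccc2n1` has not been measured. It has 2-fluorophenyl in place of 4-methoxyphenyl on an amine nitrogen in a ring, (2-fluorophenyl in place of 4-methoxyphenyl on an amine nitrogen in a ring). Among the compounds with values here, the closest precedent is the exchange of one substituted phenyl for another, a 1.8-fold higher number from compound 2 to compound 3 (0.27 log units; within the scatter). The larger steps, a 5.8-fold lower number from compound 1 to compound 2 (0.76 log units; beyond the scatter) and a 3.1-fold lower number from compound 1 to compound 3 (0.50 log units; beyond the scatter), replace methyl and bear less directly on this change. Within the data shown here, no measured compound carries 2-fluorophenyl, so the range stays wide. The expected size is no step beyond the scatter, with a slight lean to a higher number: a 1.5-fold higher number from compound 2 to compound 4 (0.18 log units; within the scatter) is the estimated step. Compound 4 is estimated at 2400 nM, with an expected range of 1100 nM to 5500 nM.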

Compound 4, half-maximal inhibitory concentration: 6460 nM
Estimate against measurement, compound 4: 2.7-fold (0.43 log units) below, outside the stated range (above it).
By their numbers in this assay, from the lowest: compounds 2 and 3 (each within the scatter of the next); then compounds 4 and 1 (each within the scatter of the next).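

In this assay the substituted phenyl groups on this amine nitrogen are not interchangeable: a 4.1-fold higher number from compound 2 to compound 4 (0.61 log units; beyond the scatter) and a 2.2-fold higher number from compound 3 to compound 4 (0.34 log units; beyond the scatter) both lie beyond the scatter, whereas a 1.8-fold higher number from compound 2 to compound 3 (0.27 log units; within the scatter) does not. A substituted phenyl here therefore does not by itself bring the gain over methyl seen with compound 2 and compound 3: a 1.4-fold lower number from compound 1 to compound 4 (0.15 log units; within the scatter) stays within the scatter. Of the three substituted phenyl groups shown, only 2-fluorophenyl gives that gain up.

The compounds shown leave open whether the fluorine itself or its placing sets compound 4 apart, a question that unsubstituted phenyl and 4-fluorophenyl on the same nitrogen would address. No measurement at hand explains why these phenyl groups differ.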